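Same Atoms, One Drawn Double Bond: Compound 2 to Compound 3

The compounds below may be only part of what the source reports. "The series", "measured", "known", "first", "only" and "open" are said of these compounds alone.

In a functional assay on MCF7 cells (Homo sapiens) for cytotoxicity, read by MTT assay, with a stated time of 48 h (on this read-out higher numbers stand for weaker inhibition and lower numbers for stronger inhibition), compound 1 (`C/C(=N/NC(=S)Nc1ccc(F)cc1)c1ccccn1`) gives 1.2 nM and compound 2 (`CC(=NNC(=S)Nc1ccc(I)cc1)c1ccccn1`) gives 6.6 nM as its result. Compound 2 thus holds the higher of the two numbers, and its gap to compound 1 lies beyond the usual scatter. Compound 3 (`C/C(=N/NC(=S)Nc1ccc(I)cc1)c1ccccn1`) has not yet been measured. It differs from compound 2 only in how it is drawn: the two compounds have the same atoms and bonds; at least one stereo element is drawn with a configuration in one of them and without one in the other: 1 of 1 stereo elements differ; a double bond is drawn without a configuration in compound 2 and Z in compound 3 and nothing leaves or enters. Compound 2 at 6.6 nM is the nearest guide, so no step beyond the scatter is expected in this assay for this change. The expected move is a 1.1-fold lower number from compound 2 to compound 3 (0.04 log units; within the scatter) and it should stay within that scatter. Compound 3 is estimated at 6 nM with an expected range from 2 nM to 15 nM as the span of likely results.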

Compound 3, half-maximal inhibitory concentration: 6.61 nM
For compound 3 the middle estimate is 1.1-fold (0.04 log units) below the measured one; measured number inside the range.
By their numbers in this assay, from the lowest: compound 1; then compounds 2 and 3 (each within the scatter of the next).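

In this assay the step is a 1.0-fold higher number from compound 2 to compound 3 (0.00 log units; within the scatter) and so gives no sign that drawing this double bond as Z changes the number. The two compounds are separated by one thing only: the fact that one of compounds 2 and 3 is drawn with a defined configuration and the other without, at the place where they differ. With the double bond now drawn alike in both compounds, the step of a 5.5-fold higher number from compound 1 to compound 3 (0.74 log units; beyond the scatter) stands for iodo in place of fluoro on an aromatic carbon alone, and it remains beyond the scatter, a comparison that the undrawn double bond of compound 2 had left unclean.

The compounds shown leave open how a compound with the opposite configuration at this double bond would read in this assay. They also leave open where a chloro, a bromo or a methoxy group in place of the iodo would fall.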